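The compounds below may be only part of what the source reports. "The series", "measured", "known", "first", "only" and "open" are said of these compounds alone.

Measured compounds:

Compound 1 `COc1cccc(-c2cc(COc3ccc4oc(=O)ccc4c3)on2)c1` — in a functional assay on COLO 205 cells (Homo sapiens) for cytotoxicity, read by MTT assay, with a stated time of 48 h (on this read-out higher numbers stand for weaker inhibition and lower numbers for stronger inhibition), compound 1 gives "not determined" (no result reported), so no result is reported for it.
Compound 2 `O=c1ccc2cc(OCc3cc(-c4ccc(Cl)cc4)no3)ccc2o1` — in this assay compound 2 gives 44500 nM.

Compound 2 therefore stands alone on the numbers shown: it is the only compound with a value, and compound 1 contributes no number against which it could be ranked, so no step between measured compounds exists. Compound 3 `O=c1ccc2cc(OCc3cc(-c4cccc([N+](=O)[O-])c4)no3)ccc2o1` differs from compound 2 in one place, (3-nitrophenyl in place of 4-chlorophenyl on an aromatic carbon), that is, 3-nitrophenyl in place of 4-chlorophenyl on an aromatic carbon. Among the measured compounds shown here, with no measured step to lean on, the expectation for this change rests on the single value of compound 2 alone. The step from compound 2 to compound 3 is expected to be a 1.1-fold lower number from compound 2 to compound 3 (0.05 log units; within the scatter), a change of no more than the usual scatter in either direction. On that basis compound 3 is estimated at 40000 nM in this assay, with a range from 15000 nM to 110000 nM.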

Compound 3, half-maximal inhibitory concentration: 48300 nM
Compound 3: middle estimate off by 1.2-fold (0.08 log units), on the low side; the range from low to high includes it.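

Among the compounds shown here, the step of a 1.1-fold higher number from compound 2 to compound 3 (0.04 log units; within the scatter) in this assay is the first that can be read at this position, the aromatic carbon of the five-membered ring next to the ring nitrogen. It shows that 3-nitrophenyl can stand in place of 4-chlorophenyl with the difference remaining within the scatter, even though the entering group carries hydrogen-bond acceptors and the leaving group has none. No measurement offered here bears on why the two compounds read alike.

The compounds shown leave open whether a group that is not a substituted phenyl ring at this carbon, such as a simple amine, a carboxylic acid or a longer alkyl chain, would move the number beyond the scatter. They also leave open how 3-chlorophenyl or 4-nitrophenyl would read there, which would separate the identity of the substituent from its place on the phenyl ring.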